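Replacing an amide hydrogen with cyclopentyl on compound 1

The source may report more compounds than this note shows. Statements on the series, on what has been measured and on what is new or still open speak of the compounds shown alone.

Compound 1 `CCC1C(=O)N(C)c2cnc(-n3ccc4cc(C(N)=O)ccc43)nc2N1c1ccn(C)n1` is a member of a small set of compounds tested in a functional assay on HeLa cells (Homo sapiens) for antiproliferative activity, read by CCK-8 assay, with a stated time of 72 h; on this read-out higher numbers stand for weaker inhibition of growth and lower numbers for stronger inhibition of growth. In this assay compound 1 gives 27400 nM, the highest of the three numbers recorded. Compound 2 `CCC1C(=O)N(C)c2cnc(Nc3ccc(S(N)(=O)=O)cc3)nc2N1c1ccn(C)n1` comes nearest: in this assay compound 2 gives 12600 nM, a difference from compound 1 that lies beyond the scatter. Compound 3 `CCNC(=O)c1ccc2c(ccn2-c2ncc3c(n2)N(C2CCCC2)[C@H](CC)C(=O)N3C)c1` is far away, and in this assay compound 3 gives 418 nM. Compound 3 differs from compound 1 in more than one place, so its much lower number cannot be traced to any single change; the two values simply show that compounds built on this shared core can reach a much stronger inhibition of growth.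

Compound 4 `CCC1C(=O)N(C)c2cnc(-n3ccc4cc(C(=O)NC5CCCC5)ccc43)nc2N1c1ccn(C)n1` has not yet been measured. For the measured compounds named here, it differs from compound 1 in one place: cyclopentyl in place of hydrogen on an amide-type nitrogen A step in this assay that stays within the scatter is possible, but a modest move toward a lower number is expected, because compound 3, the only compound here with a substituted amide nitrogen, gives 418 nM. The step from compound 1 to compound 4 is therefore estimated as a 3.0-fold lower number from compound 1 to compound 4 (0.48 log units; beyond the scatter). Compound 4 is expected to give about 9000 nM, within a range from 2500 nM to 30000 nM.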

Compound 4, concentration for 50% growth inhibition: 27400 nM
Compound 4: the middle estimate sits 3.0-fold (0.48 log units) below what was measured; low and high end bracket the measured number.
By their numbers in this assay, from the lowest: compound 3; then compound 2; then compounds 1 and 4 (each within the scatter of the next).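

In this assay, for the compounds shown here, the swap of cyclopentyl in place of hydrogen on the amide-type nitrogen gives no change at the digits printed from compound 1 to compound 4 (within the scatter) and this is the first comparison in the set in which only one place differs, so it is the first direct look at this position. It shows that the amide hydrogen can be given up and five carbon atoms in a non-aromatic ring added there, yet compound 1 and compound 4 cannot be told apart on this read-out, and both remain among the higher numbers of the set. Nothing available here explains why this change leaves the two compounds indistinguishable.

One substituent on this nitrogen says little about the position as a whole, and a single result cannot show whether every group placed there would behave the same way. A chain ending in an amine on the same nitrogen, or a carboxylic acid in place of the whole carbamoyl group, would test whether this place can move the number at all on the core of compound 1.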